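Replacing chloro with methoxy in compound 3

The compounds below may be only part of what the source reports. "The series", "measured", "known", "first", "only" and "open" are said of these compounds alone.

In a functional assay on MOLT-4 cells (Homo sapiens) for antiproliferative activity, read by cell counting, with a stated time of 2 days (on this read-out lower numbers stand for stronger inhibition and higher numbers for weaker inhibition), compound 1 (`COc1cc(C(=O)c2sc(Nc3ccccc3)nc2N)cc(OC)c1OC`) gives 6 nM while compound 2 (`COc1ccc(Nc2nc(N)c(C(=O)c3ccc(OC)c(OC)c3)s2)cc1`) gives 37 nM and compound 3 (`COc1cc(C(=O)c2sc(Nc3ccc(Cl)cc3)nc2N)cc(OC)c1OC`) gives 110 nM as the highest of the three numbers. Compound 4 (`COc1ccc(Nc2nc(N)c(C(=O)c3cc(OC)c(OC)c(OC)c3)s2)cc1`) has not been measured yet. It differs from compound 3 by methoxy in place of chloro on an aromatic carbon, para to a large group. Among the compounds with values here, the only measured step at that carbon is an 18-fold higher number from compound 1 to compound 3 (1.26 log units; beyond the scatter) when chloro replaced hydrogen, a large step. The 4-methoxyphenyl group of compound 4 also occurs in compound 2 at 37 nM although the two differ elsewhere. Both point to a lower number, with an expected step of a 4.4-fold lower number from compound 3 to compound 4 (0.64 log units; beyond the scatter) in this assay beyond the scatter. For compound 4 the estimated value is 25 nM (expected range 5 nM to 110 nM).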

Compound 4, half-maximal inhibitory concentration: 480 nM
The estimate for compound 4 lay 19-fold (1.28 log units) below the measured number; the measured number lies above the stated range.
By their numbers in this assay, from the lowest: compound 1; then compound 2; then compound 3; then compound 4.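

Methoxy at this carbon gives a higher number than chloro, with a 4.4-fold higher number from compound 3 to compound 4 (0.64 log units; beyond the scatter), so the two groups that replace hydrogen here both weaken inhibition, and methoxy does so more, with an 80-fold higher number from compound 1 to compound 4 (1.90 log units; beyond the scatter). A methoxy added at a different aromatic carbon also weakens inhibition, with a 13-fold higher number from compound 2 to compound 4 (1.11 log units; beyond the scatter). No measurement shown explains these steps.

On these data alone, whether a fluoro, a methyl or an amine at this carbon would stay close to hydrogen remains open. So does whether that other added methoxy would have the same effect in compound 1.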